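Replacing the Side Group of Compound 2

This account rests on a few compounds, and the source may have more. Where it says the series, first, only, none or still open, it means among the compounds named here.

In a functional assay on MDA-MB-231 cells (Homo sapiens) for inhibition, read by MTT assay, with a stated time of 48 h (a higher number here means a weaker inhibitor, a lower number a stronger inhibitor), compound 1 `C[Se]c1ccc(N(C)c2nc(C3CC3)nc3ccccc23)cc1` gives 18 nM, and compound 3 `Cc1nc(N(C)c2ccc([Se]C#N)c(C)c2)c2ccccc2n1` gives 16 nM. Compound 2 `COc1ccc(N(C)c2nc(C)nc3ccccc23)cc1OCCCCCC[Se]C#N` gives 3550 nM, the highest of the three numbers. Its distance from each of the other two lies beyond the scatter, which makes compound 2 the weakest inhibitor measured so far.

Compound 4 `COc1ccc(N(C)c2nc(C)nc3ccccc23)cc1C(=O)NCC[Se]C#N` has not yet been measured. It differs from compound 2 in one place, on an aromatic carbon ortho to a methoxy group and meta to a large group: a group of 8 heavy atoms (4 carbon, 2 nitrogen, 1 oxygen, 1 selenium; no ring) in place of a group of 10 heavy atoms (7 carbon, 1 nitrogen, 1 oxygen, 1 selenium; no ring), on an aromatic carbon. For the measured compounds named here, no measured pair shows the effect of such a change, so any forecast is uncertain. Like compound 2 at 3550 nM, compound 4 carries its selenium in a side group with no ring, so it is expected to stay near that number. In this assay, a small move towards a lower number is expected, with no step beyond the scatter. The expected step is a 1.8-fold lower number from compound 2 to compound 4 (0.25 log units; within the scatter). For compound 4 the estimated value is 2000 nM, with an expected range of 400 nM to 10000 nM.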

Compound 4, half-maximal inhibitory concentration: 1250 nM
Compound 4: the middle estimate sits 1.6-fold (0.20 log units) above what was measured; the range from low to high includes it.
By their numbers in this assay, from the lowest: compounds 3 and 1 (each within the scatter of the next); then compound 4; then compound 2.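

In this assay, for the compounds shown here, the exchange of side groups gives a 2.8-fold lower number from compound 2 to compound 4 (0.45 log units; beyond the scatter), the first reading of how this position, on an aromatic carbon ortho to a methoxy group, responds to a change. It shows that the number here depends on the side group, and that the group of 8 heavy atoms, with its hydrogen-bond donor and its double bond, gives a lower number than the group of 10 heavy atoms, though both contain selenium and no ring. Nothing available explains this step.

As far as these compounds go, whether it comes from the amide or from the shorter chain stays open, since both enter in the same change. From the compounds shown here alone, how an amine, a carboxylic acid or a longer amide chain on this carbon would read also remains unknown.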